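The source may report more compounds than this note shows. Statements on the series, on what has been measured and on what is new or still open speak of the compounds shown alone.

Measured in a functional assay on HepG2 cells (Homo sapiens) for inhibition, read by MTT assay, with a stated time of 72 h; a lower number here means a stronger inhibitor, a higher number a weaker inhibitor:
compound 1 `CC1=C(C(C)CC(=O)OCCCOc2no[n+]([O-])c2S(=O)(=O)c2ccccc2)C(=O)c2c(O)cccc2C1=O` 4320 nM
compound 2 `CC1=C(CCC(=O)OCCOc2no[n+]([O-])c2S(=O)(=O)c2ccccc2)C(=O)c2c(O)cccc2C1=O` 2980 nM
compound 3 `CC1=C(C(C)CC(=O)OCC(C)COc2no[n+]([O-])c2S(=O)(=O)c2ccccc2)C(=O)c2c(O)cccc2C1=O` 3740 nM

Compound 1 gives the highest of the three numbers, yet its gaps to compound 3 and to compound 2 both lie within the scatter. Compound 4 `CC1=C(CCC(=O)OCCCOc2no[n+]([O-])c2S(=O)(=O)c2ccccc2)C(=O)c2c(O)cccc2C1=O` is not yet measured; it differs from compound 1 by hydrogen in place of methyl on a saturated chain carbon bound to a double-bonded ring carbon and a saturated chain carbon. Within the data shown here, the only measured single-site step, a 1.2-fold lower number from compound 1 to compound 3 (0.06 log units; within the scatter), likewise exchanges methyl and hydrogen on a saturated chain carbon and stayed within the scatter. Compound 2, which differs from compound 1 in more than one place, shows a number close to it. No step beyond the scatter is therefore expected in this assay. The number for compound 4 is estimated at 3500 nM, between 1800 nM and 7000 nM. This amounts to an expected step of a 1.2-fold lower number from compound 1 to compound 4 (0.09 log units; within the scatter).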

Compound 4, half-maximal inhibitory concentration: 6790 nM
Compound 4: middle estimate off by 1.9-fold (0.29 log units), on the low side; measured number inside the range.
By their numbers in this assay, from the lowest: compounds 2, 3, 1 and 4 (each within the scatter of the next, the first and the last beyond it).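

In this assay, among these compounds, the first direct reading at this position gives a 1.6-fold higher number from compound 1 to compound 4 (0.20 log units; within the scatter), so removing the methyl from the saturated chain carbon bound to a double-bonded ring carbon and a saturated chain carbon produces no step beyond the scatter. The other measured exchange of methyl and hydrogen, at a different chain carbon, gave a 1.2-fold lower number from compound 1 to compound 3 (0.06 log units; within the scatter), and it also stayed within the scatter. Nothing available bears on the cause of the new step. As far as these compounds go, whether an ethyl group, a longer chain or a hydroxyl group on this carbon would give a step beyond the scatter remains open.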